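The source may report more compounds than this note shows. Statements on the series, on what has been measured and on what is new or still open speak of the compounds shown alone.

Values in a functional assay on MDA-MB-231 cells (Homo sapiens) for cytotoxicity, read by MTT assay, with a stated time of 48 h; a higher number here means a weaker inhibitor, a lower number a stronger inhibitor:
- compound 1 `COc1cc(/C=C/c2ccc(OCCCCCC(=O)NO)cc2)cc(OC)c1`: 3560 nM
- compound 2 `COc1cc(/C=C/c2ccc(OCc3cccc(C(=O)NO)c3)cc2)cc(OC)c1`: 9220 nM
- compound 3 `COc1cc(/C=C/c2ccc(OCc3ccc(C(=O)NO)cc3)cc2)cc(OC)c1`: 6880 nM

Compound 1 sits at the low end of the numbers shown, but it is clearly separated only from compound 2. The step of a 2.6-fold higher number from compound 1 to compound 2 (0.41 log units; beyond the scatter) is modest and beyond the scatter, while the step of a 1.9-fold higher number from compound 1 to compound 3 (0.29 log units; within the scatter) stays within it. The step of a 1.3-fold lower number from compound 2 to compound 3 (0.13 log units; within the scatter) also stays within the scatter.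

Compound 4 `COc1cc(/C=C/c2ccc(OCCc3cn(CC(=O)NO)nn3)cc2)cc(OC)c1` keeps the core of compound 1 and changes the chain: 1-((hydroxycarbamoyl)methyl)-1H-1,2,3-triazol-4-yl in place of 3-(hydroxycarbamoyl)propyl on a saturated chain carbon, two bonds along the chain from an oxygen on an aromatic ring. Among the measured compounds shown here, the new group carries a five-membered aromatic ring with 3 hetero atoms, and no measured compound has such a ring, so no measured step covers this change directly.

The closest evidence is the pair of steps that replace the 4-(hydroxycarbamoyl)butyl group with a group holding a ring, a 2.6-fold higher number from compound 1 to compound 2 (0.41 log units; beyond the scatter) and a 1.9-fold higher number from compound 1 to compound 3 (0.29 log units; within the scatter). Both run toward a higher number, and neither is large. Only these two steps support that direction, so the expectation in this assay is for a modest step of similar size toward a higher number. The expected step is a 2.0-fold higher number from compound 1 to compound 4 (0.29 log units; within the scatter). Compound 4 is estimated at 7000 nM, with an expected range of 2500 nM to 20000 nM.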

Compound 4, half-maximal inhibitory concentration: 6520 nM
Compound 4: the middle estimate sits 1.1-fold (0.03 log units) above what was measured; the measured number falls inside the stated range.
By their numbers in this assay, from the lowest: compounds 1, 4, 3 and 2 (each within the scatter of the next, the first and the last beyond it).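

In this assay the step of a 1.8-fold higher number from compound 1 to compound 4 (0.26 log units; within the scatter) shows that this place, on a saturated chain carbon, two bonds along the chain from an oxygen on an aromatic ring, can carry a chain holding a five-membered aromatic ring with 3 hetero atoms without leaving the scatter. Among the compounds shown here, the ring-bearing groups among the earlier compounds were 3-(hydroxycarbamoyl)phenyl and 4-(hydroxycarbamoyl)phenyl, so this result extends the comparison to a hetero-atom ring, with 10 heavy atoms entering for 7 and 5 hydrogen-bond acceptors for 2, and no step beyond the scatter accompanies either count. Nothing at hand explains this outcome.

As far as these compounds go, it remains open whether a longer chain between the five-membered ring and the hydroxycarbamoyl group would keep the number in this range, or whether the range would shift with a shorter one. A carboxylic acid or a primary amide in place of the hydroxycarbamoyl group is also an open case, and it would show how much of the reading in this assay depends on that end group.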